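Bromine to Iodine on Two Hydrazide Cores

The source may hold more compounds than are shown below. What is called first, only, known or untested is meant among the compounds shown, and "the series" means these compounds.

The study brings together three measured compounds and one that is still to be tested. Compound 1 `O=C(N/N=C/c1cc(I)cc(I)c1O)c1ccc(Br)cc1` and compound 2 `O=C(N/N=C/c1cc(I)cc(I)c1O)c1ccc(I)cc1` are built on one core, while compound 3 `O=C(NNC(=O)c1cc(I)cc(I)c1O)c1ccc(Br)cc1` and compound 4 `O=C(NNC(=O)c1cc(I)cc(I)c1O)c1ccc(I)cc1` are built on another; the difference between the two cores is not broken down here. In a functional assay on HepG2 cells (Homo sapiens) for cytotoxicity, with a stated time of 24 h (on this read-out lower numbers stand for stronger inhibition and higher numbers for weaker inhibition), compound 1 gives 22300 nM. In this assay compound 2 gives 31800 nM. The two are joined by a single change, (iodo in place of bromo on an aromatic carbon), and the step it made is a 1.4-fold higher number from compound 1 to compound 2 (0.15 log units; within the scatter). In this assay compound 3 gives 62800 nM; its distance from compound 2 lies within the scatter, its distance from compound 1 beyond it.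

Compound 4 differs from compound 3 by iodo in place of bromo on an aromatic carbon. The place of the change is the same in both pairs, so this is the same change carried onto the second core, and it occurs twice among the compounds here. The expectation for compound 4 rests on compound 1 and compound 2, because a 1.4-fold higher number from compound 1 to compound 2 (0.15 log units; within the scatter) stayed within the scatter. Accordingly, the step from compound 3 to compound 4 is expected to be a 1.4-fold higher number from compound 3 to compound 4 (0.13 log units; within the scatter). In this assay compound 4 is estimated at 85000 nM, with a likely range from 45000 nM to 170000 nM; the scatter of such cytotoxicity numbers and the closeness of this range to the top of the tested concentrations leave open that only a limit will be reported.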

Compound 4, half-maximal inhibitory concentration: 25100 nM
The estimate for compound 4 lay 3.4-fold (0.53 log units) above the measured number; measured number below the stated range.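

In this assay, replacing bromo with iodo on the second core gave a 2.5-fold lower number from compound 3 to compound 4 (0.40 log units; beyond the scatter), a modest step but one that lies beyond the scatter. On the first core the same change gave a 1.4-fold higher number from compound 1 to compound 2 (0.15 log units; within the scatter), so the step did not carry over from one core to the other, and the two results differ measurably: the same change on two cores in this assay, a 1.4-fold higher number (0.15 log units; within the scatter) from compound 1 to compound 2 and a 2.5-fold lower number (0.40 log units; beyond the scatter) from compound 3 to compound 4, 3.6-fold (0.55 log units) apart, beyond the scatter of two such steps

This shows that, in these two pairs, the step from 4-bromophenyl to 4-iodophenyl cannot simply be transferred from the first core to the second, but it does not show which feature of the cores is responsible, how the change would behave on any further core, or whether the same difference would appear in another read-out, and each core is represented here by a single pair.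

The compounds shown leave open whether a chloro, methoxy or amino group in the same place on the aromatic ring would follow the pattern of the first core or that of the second. They also leave open whether replacing either of the iodo groups on the hydroxyl-bearing ring with a smaller halogen, such as chloro, would alter the difference between the two cores.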